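The compounds below may be only part of what the source reports. "The series", "measured", "known", "first", "only" and "open" are said of these compounds alone.

Working notes on the series. In a functional assay on HOP-62 cells (Homo sapiens) for cytotoxicity, read by sulforhodamine B assay, with a stated time of 48 h, tested at 10 uM (on this read-out lower numbers stand for a stronger effect and higher numbers for a weaker effect at the one concentration tested), compound 1 `COc1ccc(-c2cc(/C=C/C(=O)c3ccc(N)cc3)[nH]n2)cc1` gives -15%, and compound 3 `COc1ccc(-c2cc(/C=C/C(=O)c3ccc(N)cc3)[nH]n2)cc1OC` gives -1%. The step of a number 14 percentage points higher from compound 1 to compound 3 (beyond the scatter) goes with methoxy in place of hydrogen on an aromatic carbon. Compound 2 `COc1ccc(C(=O)/C=C/c2cc(-c3cc(OC)c(OC)c(OC)c3)n[nH]2)cc1OC` gives -97% in this assay, the lowest of the three numbers; the difference between the core of compound 2 and the core of compound 1 is not broken down here. Compound 4 `COc1cc(C(=O)/C=C/c2cc(-c3cc(OC)c(OC)c(OC)c3)n[nH]2)cc(OC)c1OC` is not yet measured in this assay; it differs from compound 2 by methoxy in place of hydrogen on an aromatic carbon. This is the same kind of change as from compound 1 to compound 3, though here the aromatic carbon is also meta to a methoxy group. Compound 2 already gives -97%, so little room remains downward, and the earlier step of a number 14 percentage points higher from compound 1 to compound 3 (beyond the scatter) points to a small weakening. Hence the expected step is a number 7 percentage points higher from compound 2 to compound 4 (within the scatter). Compound 4 is estimated at -90% in this assay, with a range of -100% to -70%.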

Compound 4, a percentage reported as activity, at one concentration (the size of the read-out at that concentration, not a potency): -91%
Estimate against measurement, compound 4: 1 percentage points above, within the range that was stated.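

In this assay, methoxy in place of hydrogen on an aromatic carbon gives a number 6 percentage points higher from compound 2 to compound 4 (within the scatter), so the step on this core cannot be told from no change. Set beside the earlier step, the size of the change does not differ measurably between the two cores: the same change on two cores in this assay, a number 14 percentage points higher (beyond the scatter) from compound 1 to compound 3 and a number 6 percentage points higher (within the scatter) from compound 2 to compound 4, 8 percentage points apart, within the scatter of two such steps. Going by these compounds alone, this rests on only two pairs, so it shows no more than agreement within the scatter on these two cores and does not show that the step would keep its size on any other core.

The compounds shown leave open how an amine, a carboxylic acid or a longer alkoxy chain at the same place would read in this assay. They also leave open whether either core would respond to such a group in the same way.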